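A Longer Chain on the Carbonyl Side of Compound 2

A few compounds are considered here, and "the series" means these few. Any claim that something is new, unique, unknown or untested is made for them only; others in the source may bear on it.

Measured so far:
- compound 1, `C=C[C@@](C)(/C=C/c1ccc(OC(=O)CC)cc1)CCC=C(C)C`: 60%
- compound 2, `C=C[C@@](C)(/C=C/c1ccc(OC(=O)CCCCC)cc1)CCC=C(C)C`: 54%

Both compounds share one core and differ only in the chain attached on the carbonyl side. In a functional assay on THP-1 cells (Homo sapiens) for inhibition, with a stated time of 48 h, tested at 50 uM (on this read-out higher numbers stand for more inhibition of growth at the one concentration tested and lower numbers for less inhibition of growth), compound 1 gives 60%, and compound 2 gives 54%. Compound 2 stands at the lower of the two numbers, but the step of a number 6 percentage points lower from compound 1 to compound 2 (within the scatter) is one the scatter swallows, so the two compounds cannot be told apart on these data.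

Compound 3, `C=C[C@@](C)(/C=C/c1ccc(OC(=O)CCCCCCCCCCCCCCC)cc1)CCC=C(C)C`, has not yet been measured. It differs from compound 2 by decyl in place of hydrogen on a saturated chain carbon, five bonds along the chain from a carbonyl carbon.

Within the data shown here, the only measured step that bears on this change is the chain lengthening from compound 1 to compound 2, which was a number 6 percentage points lower from compound 1 to compound 2 (within the scatter). That step was small, and the new change is of the same kind, only pushing the chain much further out. No step beyond the scatter is therefore expected from compound 2 to compound 3; the estimate for that step is a number 6 percentage points lower from compound 2 to compound 3 (within the scatter). For compound 3 the estimate is 48%, in a range from 30% to 62%.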

Compound 3, percent growth inhibition at one concentration: 62%
Compound 3: the middle estimate sits 14 percentage points below what was measured; measured number inside the range.
By their numbers in this assay, from the lowest: compounds 2, 1 and 3 (each within the scatter of the next).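

The step from the earlier pair covered only a modest lengthening, with propyl in place of hydrogen giving a number 6 percentage points lower from compound 1 to compound 2 (within the scatter). Among these compounds, the new result tests this position much harder: in this assay, decyl in place of hydrogen on a saturated chain carbon, five bonds along the chain from a carbonyl carbon, gives a number 8 percentage points higher from compound 2 to compound 3 (within the scatter), so even this far larger addition produces no step that can be told from the scatter, and growth inhibition at the one concentration tested survives a very long chain here. Nothing measured on these compounds explains this tolerance, so the result describes what the position accepts and not why it accepts it.

As far as these compounds go, these compounds carry only unbranched saturated chains on the carbonyl side, so it remains open whether an amine, a carboxylic acid or a phenyl ring in place of such a chain would be accepted as well. From the compounds shown here alone, with a single concentration behind each number, it also remains open whether full dose-response curves would separate compounds that look alike in this assay.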